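The compounds below may be only part of what the source reports. "The series", "measured", "known", "first", "only" and "open" are said of these compounds alone.

In a functional assay on MCF7 cells (Homo sapiens) for cytotoxicity, read by colorimetric assay and MTT assay (on this read-out higher numbers stand for weaker inhibition and lower numbers for stronger inhibition), compound 1 `COc1cccc2cc(-c3ccccc3)c(O)nc12` gives 10000 nM, and compound 2 `COc1cc(OC)c2cc(-c3ccccc3)c(O)nc2c1`, which carries methoxy groups at other places on the core, gives 10000 nM. Compound 3 `COc1ccc(-c2cc3cccc(OC)c3nc2O)cc1` gives 10000 nM, so it stands level with both, and none of the three separates from the others on these numbers.

Compound 4 `COc1ccc(-c2cc3c(OC)ccc(OC)c3nc2O)cc1` is built from compound 3 by one change, methoxy in place of hydrogen on an aromatic carbon: a methoxy in place of hydrogen on an aromatic carbon, para to a methoxy group. For the measured compounds named here, only one measured step is of the same kind, and it involved a different aromatic carbon: no change at the digits printed from compound 1 to compound 3 (within the scatter). That single step offers no sign that adding a methoxy moves this read-out, though it cannot show what the new carbon will do.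

The expected step in this assay is therefore no change at the digits printed from compound 3 to compound 4 (within the scatter), with no shift in either direction beyond the scatter. The estimate for compound 4 is 10000 nM, with an expected range from 3000 nM to 20000 nM.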

Compound 4, half-maximal inhibitory concentration: 10000 nM
Compound 4: middle estimate and measured number agree at the digits printed, and the stated range covers the measured number.
By their numbers in this assay, from the lowest: compounds 1, 2, 3 and 4 (each within the scatter of the next).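

In this assay the new step reads no change at the digits printed from compound 3 to compound 4 (within the scatter) and so shows that a methoxy in place of hydrogen on this aromatic carbon, para to a methoxy group, leaves the read-out where it stood. Taken with no change at the digits printed from compound 1 to compound 3 (within the scatter) in the same assay, there are now two steps of this kind, each at a different aromatic carbon, and neither moves the number. Nothing measured here offers an explanation for this flat result.

Methoxy is the only group tested at this carbon, so whether an amine, a carboxylic acid or a longer chain there would shift the number stays open. All four compounds also share the same value, so the compounds shown do not yet reveal which change to the core, if any, would move this read-out.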